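This account rests on a few compounds, and the source may have more. Where it says the series, first, only, none or still open, it means among the compounds named here.

Compound 2 `CCCCCCCCCCCNC(=O)Oc1ccc(Cl)cc1C(=O)Nc1ccc(Cl)cc1` gives, in an ADME assay for metabolic stability, read by HPLC, at pH 7.4 (a lower number here means that the compound disappears faster, a higher number that the compound lasts longer), a value of 43 h, level with compound 1 `CCCCCCCCCNC(=O)Oc1ccc(Cl)cc1C(=O)Nc1ccc(Cl)cc1`, which in this assay gives 43 h. Among the measured compounds shown here, the one measured step, no change at the digits printed from compound 1 to compound 2 (within the scatter), altered only the saturated chain and left the numbers unchanged within the scatter. Compound 3 `CCCCCCCCCCCNC(=O)Oc1ccc(Cl)cc1C(=O)Nc1ccc(Cl)c(Cl)c1` differs from compound 2 by chloro in place of hydrogen on an aromatic carbon. For the measured compounds named here, no measured step touches an aromatic ring, so nothing here points to a shift beyond the scatter in either direction. Compound 3 is therefore expected to give about 43 h in this assay, between 22 h and 86 h. The expected step is no change at the digits printed from compound 2 to compound 3 (within the scatter).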

Compound 3, half-life: 43 h
For compound 3 middle estimate and measured number coincide at the digits printed; measured number inside the range.
By their numbers in this assay, from the lowest: compounds 1, 2 and 3 (each within the scatter of the next).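

In this assay, among the compounds shown here, the first measured change on an aromatic ring, 4-chlorophenyl to 3,4-dichlorophenyl, gives no change at the digits printed from compound 2 to compound 3 (within the scatter) and so extends the flat picture from the saturated chain to the ring. This aromatic carbon, ortho to a chloro group and meta to a large group, carries a chloro in place of hydrogen without moving the half-life beyond the scatter. Nothing at hand offers an explanation for this. On these data alone, whether an amine or a carboxylic acid on this carbon would also leave the half-life level stays open.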